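The source may report more compounds than this note shows. Statements on the series, on what has been measured and on what is new or still open speak of the compounds shown alone.

Working notes on the series. Compound 1 `C=C1C[C@]23C[C@@]1(O)CC[C@H]2c1ccc(O)c(C)c1[C@@H]3Cn1cc(-c2ccccc2)nn1` is the reference point. In a functional assay on HL-60 cells (Homo sapiens) for cytotoxicity, read by MTT assay, with a stated time of 4 days (on this read-out lower numbers stand for stronger inhibition and higher numbers for weaker inhibition), compound 1 returns only a limit of the assay, > 20000 nM. Compound 2 `C=C1C[C@]23C[C@@]1(O)CC[C@H]2c1cc(Br)c(O)c(C)c1[C@@H]3Cn1cc(-c2ccccc2)nn1` carries bromo in place of hydrogen on an aromatic carbon; in this assay compound 2 likewise returns a limit, > 20000 nM. Compound 3 `C=C1C[C@]23C[C@@]1(O)CC[C@H]2c1ccc(OS(=O)(=O)c2ccc(C)cc2)c(C)c1[C@@H]3Cn1cc(-c2ccccc2)nn1` carries (4-methylphenyl)sulfonyl in place of hydrogen on the phenolic oxygen; in this assay compound 3 also returns a limit, > 20000 nM. The two steps measured so far, a step that the two limits leave unreadable from compound 1 to compound 2 and a step that the two limits leave unreadable from compound 1 to compound 3, are therefore unreadable in size and direction, the common ground being (the limit of > 20000 nM in this assay, at which 3 of the 3 values shown sit).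

Compound 4 `C=C1C[C@]23C[C@@]1(O)CC[C@H]2c1ccc(O)c(C)c1[C@@H]3Cn1cc(-c2ccc(Cl)cc2)nn1` differs from compound 1 by chloro in place of hydrogen on an aromatic carbon. Neither measured step touches the phenyl on the triazole, and neither gives a readable size, so no step beyond the scatter can be argued for in this assay in either direction. Compound 4 is expected to stay at the limit as well, with an estimated 25000 nM in this assay, ranging from 8000 nM to 80000 nM. The step this implies, a step that the limit leaves unreadable from compound 1 to compound 4, is an expectation only, unreadable in practice because compound 1 itself sits at the limit of > 20000 nM in this assay, at which 3 of the 3 values shown sit.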

Compound 4, half-maximal inhibitory concentration: > 20000 nM
Compound 4: no number, only a limit; the forecaster's own chance of this, stated with the estimate: 85%; the middle value lies beyond the limit too.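

In this assay, among the compounds shown here, compound 4 returns only a limit (> 20000 nM), so no step from compound 1 to compound 4 can be read: (the limit of > 20000 nM in this assay, at which 4 of the 4 values shown sit). The compounds shown leave open whether any change to the shared core gives a measurable value in this read-out.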